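Shortening the chain on the core of compound 1

The source may report more compounds than this note shows. Statements on the series, on what has been measured and on what is new or still open speak of the compounds shown alone.

Compound 1 `C=CCCn1c(N[C@@H]2C[C@H](c3ccccc3)CN(C)C2)nc2cc[nH]c2c1=O` stands lowest of the three compounds measured in an assay on isolated protein for binding affinity to histone acetyltransferase KAT2B (Homo sapiens), read by fluorescence, tested at 10 uM (a higher number here means that the compound stabilises the target more against heat, a lower number that the compound stabilises the target less), where compound 1 gives 1.5 degrees C. Its nearest neighbour is compound 3 `CN1C[C@H](Nc2nc3ccsc3c(=O)n2C)C[C@H](c2ccccc2)C1`, which gives 4.6 degrees C in this assay, a gap beyond the scatter; furthest is compound 2 `CN1C[C@H](Nc2nc3cc[nH]c3c(=O)n2C)C[C@H](c2ccc(O)cc2)C1`, which gives 8.4 degrees C, also beyond the scatter. Compound 4 `CCn1c(N[C@@H]2C[C@H](c3ccccc3)CN(C)C2)nc2cc[nH]c2c1=O` differs from compound 1 in one place: hydrogen in place of vinyl on a saturated chain carbon, two bonds along the chain from an aromatic nitrogen. For the measured compounds named here, no pair of measured compounds shows this change, so its effect is unknown. The step from compound 1 to compound 4 is expected to be small, a number 1.0 degrees C higher from compound 1 to compound 4 (within the scatter), likely within the scatter or only just beyond it, upward if anything. Compound 4 is therefore estimated at 2.5 degrees C, with a range from 0.5 degrees C to 5 degrees C.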

Compound 4, shift of the target's melting temperature: 4.8 degrees C
Compound 4: the middle estimate sits 2.3 degrees C below what was measured, within the range that was stated.
By their numbers in this assay, from the lowest: compound 1; then compounds 3 and 4 (each within the scatter of the next); then compound 2.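

In this assay, going from but-3-en-1-yl to ethyl on the core gives a number 3.3 degrees C higher from compound 1 to compound 4 (beyond the scatter) and so shows that this position is sensitive to the chain it carries, with the shorter, saturated chain standing higher. Nothing available explains this step.

The compounds shown leave open whether the step follows from the shorter length or the loss of the double bond, a question that a saturated butyl chain would address. As far as these compounds go, how a chain ending in an amine or a carboxylic acid would behave at this position also remains open.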